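This account rests on a few compounds, and the source may have more. Where it says the series, first, only, none or still open, it means among the compounds named here.

Measured so far in a functional assay, with a stated time of 10 min; a lower number here means a stronger inhibitor, a higher number a weaker inhibitor:

Compound 1, `COc1ccc(-c2nc(SC)n(C)c(=O)c2C#N)cc1`: 48 ug/mL
Compound 2, `COc1ccc(-c2nc(NN)n(C)c(=O)c2C#N)cc1`: 32 ug/mL
Compound 3, `CSc1nc(-c2cccs2)c(C#N)c(=O)n1C`: 72 ug/mL

Compound 1 and compound 2 share a core and differ in one place: aminoamino in place of methylsulfanyl on an aromatic carbon. That exchange gave a 1.5-fold lower number from compound 1 to compound 2 (0.18 log units; within the scatter), a step within the scatter, so the two values cannot be ranked against each other. Compound 3 carries a different core; the difference between the core of compound 3 and the core of compound 1 is not broken down here. Its value and that of compound 1 lie within the scatter of each other, while compound 2 sits beyond the scatter from compound 3.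

Compound 4, `Cn1c(NN)nc(-c2cccs2)c(C#N)c1=O`, is not yet measured. It is made from compound 3 by the same kind of change: aminoamino in place of methylsulfanyl on an aromatic carbon. The surroundings differ only in that the place is meta to a thiophen-2-yl group (5 heavy atoms) rather than meta to a group of 8 heavy atoms. Because compound 1 to compound 2 gave a 1.5-fold lower number from compound 1 to compound 2 (0.18 log units; within the scatter), a step of similar size is expected here, a 1.5-fold lower number from compound 3 to compound 4 (0.18 log units; within the scatter), in this assay. Compound 4 is thus estimated at 48 ug/mL, probably between 25 ug/mL and 95 ug/mL.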

Compound 4, half-maximal inhibitory concentration: 53 ug/mL
Compound 4: middle estimate off by 1.1-fold (0.04 log units), on the low side; low and high end bracket the measured number.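

In this assay, putting aminoamino in place of methylsulfanyl on the core of compound 3 gave a 1.4-fold lower number from compound 3 to compound 4 (0.13 log units; within the scatter) and therefore does not separate the two compounds. Set beside the earlier case, the step looks much the same on both cores: the same change on two cores in this assay, a 1.5-fold lower number (0.18 log units; within the scatter) from compound 1 to compound 2 and a 1.4-fold lower number (0.13 log units; within the scatter) from compound 3 to compound 4, 1.1-fold (0.04 log units) apart, within the scatter of two such steps. So, on these two cores, the exchange carries over as a small step that stays within the noise of the assay, but this does not show that aminoamino truly gives a stronger inhibitor than methylsulfanyl, nor that the same would hold on any third core.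

The compounds shown leave open whether a different group at this carbon, such as a simple amine, a morpholine ring or a longer alkylamine chain, would move the number by more than the scatter. They also leave open what would happen if the nitrile were replaced by a carboxylic acid or an amide.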